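The source may hold more compounds than are shown below. What is called first, only, known or untested is meant among the compounds shown, and "the series" means these compounds.

In a functional assay on U-251 cells (Homo sapiens) for inhibition, read by sulforhodamine B assay, with a stated time of 48 h (a higher number here means a weaker inhibitor of growth, a lower number a stronger inhibitor of growth), the three measured compounds all reached only the limit of the assay:

compound 1, `CC(C)(C)NCc1c(C(=O)O)nn(-c2ccccc2)c1-c1ccccc1`: > 716000 nM
compound 2, `Cc1ccc(-c2c(CNC(C)(C)C)c(C(=O)O)nn2-c2ccccc2)cc1`: > 688000 nM
compound 3, `CC(C)(C)NCc1c(C(=O)O)nn(-c2ccc(Cl)cc2)c1-c1ccccc1`: > 652000 nM

Each of these values is a limit, not a number. From compound 1 to compound 2 the change is methyl in place of hydrogen on an aromatic carbon, and the two limits leave its size unreadable: a step that the two limits leave unreadable from compound 1 to compound 2. From compound 1 to compound 3 the change is chloro in place of hydrogen on an aromatic carbon, and again a step that the two limits leave unreadable from compound 1 to compound 3. The values sit at the limit of > 716000 nM in this assay, at which 1 of the 3 values shown sits, at the limit of > 688000 nM in this assay, at which 1 of the 3 values shown sits, and at the limit of > 652000 nM in this assay, at which 1 of the 3 values shown sits, so nothing about the size of either step can be read from them.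

Compound 4, `Cc1ccc(-c2c(CNC(C)(C)C)c(C(=O)O)nn2-c2ccc(Cl)cc2)cc1`, has not yet been measured in this assay. It differs from compound 3 by methyl in place of hydrogen on an aromatic carbon, the same change as that from compound 1 to compound 2; the two place lines agree word for word, and the cores of the two pairs differ by chloro in place of hydrogen on an aromatic carbon. The first occurrence of this change gave no readable step, so the expectation for compound 4 rests on all three measured compounds sitting at a limit. The step from compound 3 to compound 4 is expected to be a step that the limit leaves unreadable from compound 3 to compound 4. Compound 4 is therefore expected to give about 700000 nM, with a range of 200000 nM to 2000000 nM, most likely again as a limit.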

Compound 4, concentration for 50% growth inhibition: > 629000 nM
Compound 4 ended at the assay's limit; the forecaster's own chance of this, stated with the estimate: 85%; the middle value is on the limit's open side.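

In this assay compound 4 gives > 629000 nM, which is a limit and not a number. The steps to compound 4 from compound 3 and from compound 2 therefore cannot be read. The compounds shown leave open whether methyl or chloro in place of hydrogen on an aromatic carbon changes growth inhibition at all, and by how much.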